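The source may report more compounds than this note shows. Statements on the series, on what has been measured and on what is new or still open speak of the compounds shown alone.

Of the compounds shown here, three sharing one core have been tested in a functional assay on Ehrlich cells (Mus musculus) for cytotoxicity, tested at 10 ug/mL; on this read-out lower numbers stand for a weaker effect and higher numbers for a stronger effect at the one concentration tested. Compound 1 `COc1cc(N2C(N)=C(C#N)C(/C=C/c3ccccc3)C3=C2CC(C)(C)CC3=O)cc(OC)c1OC` gives 10%. Compound 2 `COc1cc(N2C(N)=C(C#N)C(c3ccccc3O)C3=C2CC(C)(C)CC3=O)cc(OC)c1OC` gives 0%. Compound 3 `COc1cc(N2C(N)=C(C#N)C(c3ccc(OC)c4ccccc34)C3=C2CC(C)(C)CC3=O)cc(OC)c1OC` gives 10%. The swap of the group on the saturated ring carbon gives a number 10 percentage points lower from compound 1 to compound 2 (within the scatter), no change at the digits printed from compound 1 to compound 3 (within the scatter) and a number 10 percentage points higher from compound 2 to compound 3 (within the scatter). Compound 2 thus carries the smallest figure of the three, yet each of its steps to the others stays within the scatter, so the three results cannot be told apart with any confidence.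

Compound 4 `COc1cc(N2C(N)=C(C#N)C(c3cccs3)C3=C2CC(C)(C)CC3=O)cc(OC)c1OC` has not yet been measured in this assay. Compared with compound 2 the change is thiophen-2-yl in place of 2-hydroxyphenyl on a saturated ring carbon. Going by the values given here, the steps that bear on it are those in which the same saturated ring carbon carried a different group: a number 10 percentage points lower from compound 1 to compound 2 (within the scatter) and a number 10 percentage points higher from compound 2 to compound 3 (within the scatter), both within the scatter, and no change at the digits printed from compound 1 to compound 3 (within the scatter). Three quite different groups at this position have so far left the read-out where it was, so the thiophen-2-yl group is expected to do the same, with no step beyond the scatter in this assay. Compound 4 is therefore estimated at 5%, within a range of 0% to 20%, which means an expected step of a number 5 percentage points higher from compound 2 to compound 4 (within the scatter).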

Compound 4, a percentage reported as activity, at one concentration (the size of the read-out at that concentration, not a potency): 5%
The estimate for compound 4 equals the measured number at the digits printed, and the stated range covers the measured number.
By their numbers in this assay, from the lowest: compounds 2, 4, 1 and 3 (each within the scatter of the next).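

The thiophen-2-yl group puts a five-membered aromatic ring with a sulfur atom on the saturated ring carbon, a type of ring not seen there before, and in this assay the result is a number 5 percentage points higher from compound 2 to compound 4 (within the scatter), a number 5 percentage points lower from compound 3 to compound 4 (within the scatter) and a number 5 percentage points lower from compound 1 to compound 4 (within the scatter). The swap from compound 2 also replaces a group with a hydrogen-bond donor by one with none, and no step beyond the scatter comes with it, so four different groups on this carbon now give results that cannot be told apart. Nothing available explains why these results stay so close together.

It remains open whether any group on this carbon can shift the read-out beyond the scatter, for example an amine, a carboxylic acid or a longer alkyl chain, since the groups shown are all built around aromatic rings. The figures also come from a single concentration, so they leave open how these compounds would compare at other concentrations.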